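This account rests on a few compounds, and the source may have more. Where it says the series, first, only, none or still open, it means among the compounds named here.

Measured compounds:
compound 1 `CC1=C(C(=O)OCC(C)C)C(c2ccsc2)NC(=S)N1` gives 15%
compound 2 `CC1=C(C(=O)OC(C)(C)C)C(c2ccoc2)NC(=O)N1C` gives 16%
compound 3 `CCNC(=O)C1=C(C)NC(=O)NC1c1ccco1` gives 1%

All three numbers come from an assay on membranes from HEK293 cells for displacement of a labelled ligand from adenosine receptor A2b (Homo sapiens), read by scintillation counting, with a stated time of 30 min, tested at 1 uM; on this read-out lower numbers stand for less inhibition and higher numbers for more inhibition at the one concentration tested (going by the name of the read-out). Compound 3 stands lowest of the three. Its nearest neighbour is compound 1, whose number lies higher by an amount beyond the scatter, and compound 2 lies further off, also beyond the scatter. Compound 1 and compound 2 lie within the scatter of each other, so nothing separates them on this read-out. Among the measured compounds shown here, no pair of measured compounds differs in a single place, so no measured step is available to lean on.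

Compound 4 `CCN(CC)C(=O)C1=C(C)NC(=O)NC1c1ccco1` is not yet measured. It differs from compound 3 by ethyl in place of hydrogen on an amide-type nitrogen. Cut one bond further out, the same difference reads ethylamino to diethylamino.

For the measured compounds named here, with no measured step of this kind, the expectation for this assay is a step of no size beyond the scatter, if anything upward: compound 3 already gives 1%, which leaves almost no room for a lower number. The step from compound 3 to compound 4 is expected as a number 4 percentage points higher from compound 3 to compound 4 (within the scatter). Compound 4 is estimated at 5%, within a range from 0% to 20%.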

Compound 4, a percentage reported as inhibition, at one concentration (the size of the read-out at that concentration, not a potency): 31%
Beside the measured number, compound 4's estimate is 26 percentage points below it; the whole stated range lies below it.
By their numbers in this assay, from the lowest: compound 3; then compounds 1 and 2 (each within the scatter of the next); then compound 4.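

Working notes on the amide position: in this assay, ethyl in place of hydrogen on an amide-type nitrogen gives a number 30 percentage points higher from compound 3 to compound 4 (beyond the scatter), the first step in the series that can be read at a single place, and it shows that this nitrogen is a position at which the read-out can move. The change, ethylamino to diethylamino, removes the amide hydrogen and adds 2 carbon atoms with no ring, and on this one pair that swap raises the number rather than leaving it unchanged. No measurement shown here accounts for the size or direction of this step, so it stands as an observation only.

Among the compounds shown here, the single pair does not separate the loss of the amide hydrogen from the gain of the ethyl group, and a methyl group on the same nitrogen, a longer chain such as propyl or butyl, or a pyrrolidine amide would be needed to draw that line. Going by these compounds, whether the step carries over to the ester compounds, or to a carboxylic acid at the same place, remains open, as does what the number at this one concentration would mean as a potency.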